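The source may report more compounds than this note shows. Statements on the series, on what has been measured and on what is new or still open speak of the compounds shown alone.

Compound 1 `COC(=O)C1=C(C)NC(C)=C(C(=O)OC)C1c1cnc(SC)n1Nc1ccccc1` gives 3.54 nM
Compound 2 `CSc1ncc(C2C(C(=O)OC(C)C)=C(C)NC(C)=C2C(=O)OC(C)C)n1Nc1ccccc1` gives 2.16 nM
Compound 3 `CCCOC(=O)C1=C(C)NC(C)=C(C(=O)OC)C1c1cnc(SC)n1Nc1ccccc1` gives 2.4 nM

These three compounds share one core and differ only in their ester groups. All were tested in an assay on isolated protein (strain albino) for antagonist activity at Voltage-dependent L-type calcium channel subunit alpha-1C (Cavia porcellus); a lower number here means a stronger inhibitor, a higher number a weaker inhibitor. Among the three numbers, compound 3 stands second highest; its nearest neighbour is compound 2 and its furthest is compound 1, and both gaps lie within the usual scatter of this assay. Within the data shown here, the one single-point step among the measured compounds, a 1.5-fold lower number from compound 1 to compound 3 (0.17 log units; within the scatter), lengthens a short ester chain and also stays within the scatter, so nothing measured so far separates these compounds beyond noise.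

Compound 4 `COC(=O)C1=C(C)NC(C)=C(C(=O)OC(C)C)C1c1cnc(SC)n1Nc1ccccc1` has not yet been measured. It differs from compound 3 by isopropyl in place of propyl on an oxygen next to a carbonyl group. Among the measured compounds shown here, no measured step makes this exact exchange. The step that bears most closely on it is a 1.5-fold lower number from compound 1 to compound 3 (0.17 log units; within the scatter), which changed the same ester chain and produced no shift beyond the scatter. For the measured compounds named here, compound 2, the only measured compound carrying isopropyl groups, gives a number close to that of compound 3. The expected step of a 1.0-fold lower number from compound 3 to compound 4 (0.02 log units; within the scatter) is therefore none beyond the scatter. Compound 4 is expected to give about 2.3 nM, within a range from 1 nM to 5 nM.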

Compound 4, half-maximal inhibitory concentration: 6.35 nM
The estimate for compound 4 lay 2.8-fold (0.44 log units) below the measured number, and the stated range ends below it.
By their numbers in this assay, from the lowest: compounds 2, 3, 1 and 4 (each within the scatter of the next, the first and the last beyond it).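

Among these compounds, this ester position does respond in this assay, and even a rearrangement of the same three carbons registers: with propyl exchanged for isopropyl on an oxygen next to a carbonyl group, the result is a 2.6-fold higher number from compound 3 to compound 4 (0.42 log units; beyond the scatter), the first step in this set to pass beyond the scatter. The second ester also matters once isopropyl is present, since methyl in place of isopropyl there gives a 2.9-fold higher number from compound 2 to compound 4 (0.47 log units; beyond the scatter), so a single isopropyl ester paired with a methyl ester does not match the compound with isopropyl on both. Against the compound with methyl on both esters, the single isopropyl gives a 1.8-fold higher number from compound 1 to compound 4 (0.25 log units; within the scatter), which stays within the scatter, so the clear differences appear only in the comparisons with propyl and with the second isopropyl.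

No measurement shown accounts for these differences. Going by these compounds, it also remains open how a longer chain such as butyl, a tert-butyl group, or a chain ending in an amine on this same oxygen would compare with propyl and isopropyl.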